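Predicting solubility after ethylating the primary amide of compound 3

The source may hold more compounds than are shown below. What is called first, only, known or untested is meant among the compounds shown, and "the series" means these compounds.

Compound 1 `CNC(=O)c1cc(C(=O)NC2CCC2)cn(Cc2ccccc2)c1=O`: in a physicochemical assay for solubility (on this read-out lower numbers stand for lower solubility and higher numbers for higher solubility), compound 1 gives 28 ug/mL.
Compound 2 `CNC(=O)c1cc(C(=O)NCCO)cn(Cc2ccccc2)c1=O`: compound 2 gives only a limit of this assay, >= 140 ug/mL.
Compound 3 `CNC(=O)c1cc(C(N)=O)cn(Cc2ccccc2)c1=O`: compound 3 gives 71 ug/mL.

Among the two plain numbers, compound 3 stands highest, with a 2.5-fold higher number from compound 1 to compound 3 (0.40 log units; beyond the scatter). Compound 2 cannot be ordered against it, since it reached the limit of this assay the limit of >= 140 ug/mL in this assay, at which 1 of the 3 values shown sits, and an at least 1.9-fold lower number from compound 2 to compound 3 (0.29 log units; that floor lies within the scatter).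

Compound 4 `CCNC(=O)c1cc(C(=O)NC)c(=O)n(Cc2ccccc2)c1` is not yet measured. It differs from compound 3 by ethyl in place of hydrogen on an amide-type nitrogen, that is, carbamoyl becomes ethylcarbamoyl. The step that bears on this is the one in the opposite sense, where a cyclobutyl was replaced by hydrogen: a 2.5-fold higher number from compound 1 to compound 3 (0.40 log units; beyond the scatter). Adding a carbon chain back onto that same nitrogen is therefore expected to lower solubility, though ethyl is smaller than cyclobutyl, so the expected step is a 1.8-fold lower number from compound 3 to compound 4 (0.25 log units; within the scatter). Compound 4 is accordingly estimated at 40 ug/mL, with a range from 18 ug/mL to 90 ug/mL.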

Compound 4, solubility: >= 144 ug/mL
Compound 4: a limit, no number (the forecaster's own chance of this, stated with the estimate: 5%); middle value at least 3.6-fold (0.55 log units) from the limit.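

In this assay, compound 4 gives only a limit, not a plain number: the limit of >= 144 ug/mL in this assay, at which 1 of the 4 values shown sits. Ethyl in place of cyclobutyl gives an at least 5.1-fold higher number from compound 1 to compound 4 (0.71 log units; beyond the scatter) and so these two groups are not interchangeable on this amide-type nitrogen. Ethyl in place of the amide hydrogen gives an at least 2.0-fold higher number from compound 3 to compound 4 (0.30 log units; that floor lies within the scatter) and so, at least for ethyl, a carbon chain on this nitrogen need not go with a lower number.

Compound 2 and compound 4 are both limits, and the step between them cannot be read. On these data alone, the true number for compound 4 stays open, as does whether a longer chain such as butyl, or an amine at the end of the ethyl, would give a plain number on this nitrogen.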